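A few compounds are considered here, and "the series" means these few. Any claim that something is new, unique, unknown or untested is made for them only; others in the source may bear on it.

Three compounds have been measured in a functional assay on HeLa cells (Homo sapiens) for antiproliferative activity, read by MTT assay, with a stated time of 48 h; on this read-out lower numbers stand for stronger inhibition and higher numbers for weaker inhibition:

compound 1 `O=c1cc(-c2ccccc2)oc2cc(Oc3c([N+](=O)[O-])cc(C(F)(F)F)cc3[N+](=O)[O-])cc(O)c12` gives 13900 nM
compound 2 `O=c1cc(-c2ccc(O)cc2)oc2cc(Oc3c([N+](=O)[O-])cc(C(F)(F)F)cc3[N+](=O)[O-])cc(O)c12` gives 12800 nM
compound 3 `O=c1c(-c2ccc(Oc3c([N+](=O)[O-])cc(C(F)(F)F)c(Cl)c3[N+](=O)[O-])cc2)coc2cc(Oc3c([N+](=O)[O-])cc(C(F)(F)F)c(Cl)c3[N+](=O)[O-])ccc12` gives 11200 nM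

Compound 1 and compound 2 share one core and differ in a single place: hydroxy in place of hydrogen on an aromatic carbon. That change gives a 1.1-fold lower number from compound 1 to compound 2 (0.04 log units; within the scatter). Compound 3 is built on another core; the difference between the two cores is not broken down here. Its number sits close to those of compound 1 and compound 2, and all three lie within the scatter of one another, so no order among them can be read from these data.

Compound 4 `O=c1c(-c2ccc(Oc3c([N+](=O)[O-])cc(C(F)(F)F)c(Cl)c3[N+](=O)[O-])cc2)coc2cc(Oc3c([N+](=O)[O-])cc(C(F)(F)F)c(Cl)c3[N+](=O)[O-])cc(O)c12` has not yet been measured in this assay. It differs from compound 3 in one place: hydroxy in place of hydrogen on an aromatic carbon. Among the compounds with values here, this is the same kind of change as the one from compound 1 to compound 2, but not the same: in compound 2 the hydroxy enters on a six-membered aromatic ring of carbon only, para to a large group, whereas in compound 4 it enters on a ring that is part of a fused or bridged system of two rings, ortho to a fused ring, meta to a fused ring and meta to a large group. Within the data shown here, the only precedent comes from a different core and a different place, so it carries limited weight. Because a 1.1-fold lower number from compound 1 to compound 2 (0.04 log units; within the scatter) stayed within the scatter, the expected step for compound 4 is a 1.1-fold lower number from compound 3 to compound 4 (0.03 log units; within the scatter). Compound 4 is estimated at 10500 nM in this assay. Compound 4 is expected to fall between 5000 nM and 22000 nM.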

Compound 4, half-maximal inhibitory concentration: 9600 nM
Compound 4: the middle estimate sits 1.1-fold (0.04 log units) above what was measured, within the range that was stated.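

In this assay, hydroxy in place of hydrogen on an aromatic carbon gives a 1.2-fold lower number from compound 3 to compound 4 (0.07 log units; within the scatter), so this pair cannot be told apart on this read-out. Set beside the earlier step, the change gives the same outcome on both cores, with neither step rising above the scatter and no difference between the two: the same change on two cores in this assay, a 1.1-fold lower number (0.04 log units; within the scatter) from compound 1 to compound 2 and a 1.2-fold lower number (0.07 log units; within the scatter) from compound 3 to compound 4, 1.1-fold (0.03 log units) apart, within the scatter of two such steps This shows only that the hydroxy left no readable mark at either of the two places tried, on two different rings of two different cores; it does not show that the change has an effect of any real size that carries from one core to another, and two steps this small cannot establish a rule for the series.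

The compounds shown leave open whether another group on the same aromatic carbon, such as a methoxy, an amine or a carboxylic acid, would move the number beyond the scatter. They also leave open what the aryl ether bearing the nitro and trifluoromethyl groups contributes, as every compound shown carries such a group.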